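The source may report more compounds than this note shows. Statements on the series, on what has been measured and on what is new or still open speak of the compounds shown alone.

Measured compounds:
compound 1 `CC(C)C(C)(C)/N=C(\NC#N)Nc1cccnc1` gives 1 mg/kg in a functional assay on the whole organism (blood, strain Wistar-Okamoto) with Rattus norvegicus as the target, with a stated time of 5 days; a lower number here means that less compound is needed, a higher number that more compound is needed for the effect.
compound 2 `CC(C)(C)C(C)(C)/N=C(\NC#N)Nc1cccnc1` gives 50 mg/kg in this assay.

Going by the values given here, of these two numbers in this assay, compound 2 stands highest; the only other compound, compound 1, sits below it by a 50-fold higher number from compound 1 to compound 2 (1.70 log units; beyond the scatter). Compound 3 `CC(C)(C)CC(C)(C)/N=C(\NC#N)Nc1cccnc1` carries a different change at the same site: neopentyl in place of tert-butyl on a saturated chain carbon bound to a double-bonded nitrogen and two saturated chain carbons. Among the compounds with values here, the one step that bears on it is a 50-fold higher number from compound 1 to compound 2 (1.70 log units; beyond the scatter), where adding a methyl at that carbon raised the dose sharply. Adding a further carbon by the neopentyl is expected to give roughly a 1.7-fold lower number from compound 2 to compound 3 (0.22 log units; within the scatter), a change not clearly beyond the scatter. Compound 3 is therefore estimated at 30 mg/kg, in the range 5 mg/kg to 150 mg/kg.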

Compound 3, minimum effective dose: 50 mg/kg
Compound 3: the middle estimate sits 1.7-fold (0.22 log units) below what was measured; measured number inside the range.
By their numbers in this assay, from the lowest: compound 1; then compounds 2 and 3 (each within the scatter of the next).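

In this assay neopentyl in place of tert-butyl on a saturated chain carbon bound to a double-bonded nitrogen and two saturated chain carbons gives no change at the digits printed from compound 2 to compound 3 (within the scatter) and so leaves the dose where compound 2 put it. Neopentyl in place of isopropyl gives a 50-fold higher number from compound 1 to compound 3 (1.70 log units; beyond the scatter) and so matches the rise already seen with tert-butyl, which means two different groups now share the high dose at this site. No available evidence explains this. The compounds shown leave open whether an ethyl, a cyclopropyl or a chain ending in a hydroxyl at this carbon would stay near compound 1 or join compounds 2 and 3.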